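Nitro in Place of Methoxy at Low Growth Inhibition

A few compounds are considered here, and "the series" means these few. Any claim that something is new, unique, unknown or untested is made for them only; others in the source may bear on it.

Of the compounds shown here, two sharing one core have been measured in a functional assay on HO8910 cells (Homo sapiens) for inhibition, read by MTT assay, with a stated time of 24 h, tested at 1 ug/mL; a higher number here means more inhibition of growth at the concentration tested, a lower number less inhibition of growth. Compound 1 (`O=C(CCCCC(S)CCS)Nc1ccc(OC(F)(F)F)cc1`) gives 0.56%, and compound 2 (`COc1ccc(NC(=O)CCCCC(S)CCS)cc1`) gives 1.79%. Compound 2 cannot be told apart from compound 1 on these numbers, and both show very little inhibition of growth at the concentration tested.

Compound 3 (`O=C(CCCCC(S)CCS)Nc1ccc([N+](=O)[O-])cc1`) has nitro in place of methoxy on an aromatic carbon, para to a large group: nitro in place of methoxy on an aromatic carbon. Among the compounds with values here, only one measured step bears on this change, methyl in place of trifluoromethyl on an oxygen on an aromatic ring. That step is a number 1.2 percentage points higher from compound 1 to compound 2 (within the scatter). Within the data shown here, it is a small step, but it is only indirect evidence, as no measured compound carries nitro. With that single step to go on, no change beyond the scatter is expected in this assay, and no direction is favoured with any confidence. The estimated step is a number 1.2 percentage points higher from compound 2 to compound 3 (within the scatter). Compound 3 is expected to give 3%, with an estimated range from 0% to 12%.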

Compound 3, percent growth inhibition at one concentration: 0.76%
For compound 3 the middle estimate is 2.2 percentage points above the measured one; the range from low to high includes it.
By their numbers in this assay, from the lowest: compounds 1, 3 and 2 (each within the scatter of the next).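

In this assay, nitro in place of methoxy gives a number 1 percentage points lower from compound 2 to compound 3 (within the scatter), and nitro in place of trifluoromethoxy gives a number 0.2 percentage points higher from compound 1 to compound 3 (within the scatter). On an aromatic carbon para to a large group, nitro therefore cannot be told apart from either methoxy or trifluoromethoxy, so a group carrying nitrogen joins the two oxygen-linked groups, and this position has yet to separate any of the three. All three compounds still show very little inhibition of growth at the concentration tested, and nothing available here offers an explanation for how closely they agree.

The compounds shown leave open whether an amine or a carboxylic acid on this same aromatic carbon would move the number beyond the scatter. They also leave open whether a change away from the ring, such as a hydroxyl in place of a thiol or a longer chain in the shared core, would produce a reading that could be separated from these three.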